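Removing two methoxy groups from a terphenyl benzimidazole series

This account rests on a few compounds, and the source may have more. Where it says the series, first, only, none or still open, it means among the compounds named here.

Measured so far:
compound 1 `c1ccc(-c2ccc(-c3ccc(-c4nc5ccccc5[nH]4)cc3)cc2)cc1`, 100000 nM
compound 2 `COc1ccc(-c2ccc(-c3ccc(-c4nc5cc(C)ccc5[nH]4)cc3)cc2)cc1OC`, 3510 nM
compound 3 `COc1ccc(-c2ccc(-c3ccc(-c4nc5ccccc5[nH]4)cc3)cc2)cc1OC`, 6200 nM

Three compounds share a terphenyl-type chain ending in a benzimidazole core and have been tested in a functional assay on SiHa cells (Homo sapiens) for inhibition, read by sulforhodamine B assay; a lower number here means a stronger inhibitor of growth, a higher number a weaker inhibitor of growth. Compound 3 gives 6200 nM in this assay, and compound 1 gives 100000 nM. Between them lies one change, (phenyl in place of 3,4-dimethoxyphenyl on an aromatic carbon), which produced a large step: a 16-fold higher number from compound 3 to compound 1 (1.21 log units; beyond the scatter). Compound 2, which gives 3510 nM, differs from compound 3 only in its core, (methyl in place of hydrogen on an aromatic carbon), and the two sit close: a 1.8-fold higher number from compound 2 to compound 3 (0.25 log units; within the scatter).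

Compound 4 `Cc1ccc2[nH]c(-c3ccc(-c4ccc(-c5ccccc5)cc4)cc3)nc2c1` is not yet measured. It arises from compound 2 by the same change seen before, (phenyl in place of 3,4-dimethoxyphenyl on an aromatic carbon), at the same place. Since the cores of compound 2 and compound 3 behave alike, a step of similar size is expected, a 16-fold higher number from compound 2 to compound 4 (1.20 log units; beyond the scatter), resting on the large step from compound 3 to compound 1 a 16-fold higher number from compound 3 to compound 1 (1.21 log units; beyond the scatter). Compound 4 is therefore estimated at 56000 nM, likely between 20000 nM and 120000 nM.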

Compound 4, concentration for 50% growth inhibition: 35200 nM
Estimate against measurement, compound 4: 1.6-fold (0.20 log units) above; the measured number falls inside the stated range.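

On both cores in this assay, phenyl in place of 3,4-dimethoxyphenyl gives a clearly weaker inhibitor of growth, and the new step, a 10-fold higher number from compound 2 to compound 4 (1.00 log units; beyond the scatter), agrees with the earlier one: the same change on two cores in this assay, a 16-fold higher number (1.21 log units; beyond the scatter) from compound 3 to compound 1 and a 10-fold higher number (1.00 log units; beyond the scatter) from compound 2 to compound 4, 1.6-fold (0.21 log units) apart, within the scatter of two such steps. The methyl on the core can be read the same way, with a 2.8-fold lower number from compound 1 to compound 4 (0.45 log units; beyond the scatter) set against a 1.8-fold higher number from compound 2 to compound 3 (0.25 log units; within the scatter), and although only the first of these lies beyond the scatter, the two steps do not differ from each other: the same change on two cores in this assay, a 1.8-fold higher number (0.25 log units; within the scatter) from compound 2 to compound 3 and a 2.8-fold higher number (0.45 log units; beyond the scatter) from compound 4 to compound 1, 1.6-fold (0.21 log units) apart, within the scatter of two such steps. This shows that the change carried over between two cores that differ by a single methyl, but it does not show that the change would carry over to a more different core, and it does not explain why the two methoxy groups matter.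

From the compounds shown here alone, it remains open whether a single methoxy group would serve as well as two, or how a hydroxyl, an amine or a carboxylic acid would behave in their place. Also open, going by these compounds, is how a chlorine or a nitrile in place of the methyl on the core would affect these steps.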